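Second Butyl on the Amide Nitrogen of a Stilbene Series

This account rests on a few compounds, and the source may have more. Where it says the series, first, only, none or still open, it means among the compounds named here.

Measured so far in a functional assay on A549 cells (Homo sapiens) for inhibition, read by MTT assay, with a stated time of 48 h; a lower number here means a stronger inhibitor, a higher number a weaker inhibitor:
compound 1 `COc1ccc(/C=C/c2cc(OC)cc(OC)c2/C=C/C(=O)N2CCN(C)CC2)cc1` gives 4510 nM
compound 2 `CCCCNC(=O)/C=C/c1c(/C=C/c2ccc(OC)cc2)cc(OC)cc1OC` gives 1880 nM

Compound 2 stands lowest of the two numbers; the step of a 2.4-fold lower number from compound 1 to compound 2 (0.38 log units; beyond the scatter) is modest and came from a change on the carbonyl carbon. Compound 3 `CCCCN(CCCC)C(=O)/C=C/c1c(/C=C/c2ccc(OC)cc2)cc(OC)cc1OC` differs from compound 2 only by butyl in place of hydrogen on an amide-type nitrogen. Among the compounds with values here, no measured step alters the amide-type nitrogen itself, so only the modest step of a 2.4-fold lower number from compound 1 to compound 2 (0.38 log units; beyond the scatter) bears on this change, and loosely. The expected step of a 1.1-fold higher number from compound 2 to compound 3 (0.03 log units; within the scatter) is therefore small, likely within the scatter in either direction. Compound 3 is expected to give about 2000 nM, with a range from 800 nM to 5000 nM.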

Compound 3, half-maximal inhibitory concentration: 6160 nM
Compound 3: middle estimate off by 3.1-fold (0.49 log units), on the low side; the measured number lies above the stated range.
By their numbers in this assay, from the lowest: compound 2; then compounds 1 and 3 (each within the scatter of the next).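

In this assay, the amide-type nitrogen, which no earlier step had changed, is now shown to be sensitive: butyl in place of hydrogen gives a 3.3-fold higher number from compound 2 to compound 3 (0.52 log units; beyond the scatter) and loses the lead held by compound 2. Dibutylamino and 4-methylpiperazin-1-yl on the carbonyl carbon show a 1.4-fold higher number from compound 1 to compound 3 (0.14 log units; within the scatter), so among these three groups only butylamino stands apart. Nothing measured here gives a reason for these steps.

Still open, as far as these compounds go, is whether a smaller group such as methyl or ethyl on that nitrogen is tolerated. Also open, from the compounds shown here alone, is whether a longer chain than butyl in place of the butylamino chain would keep or lower the number of compound 2.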